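Trifluoroethyl for Dimethylamino: Expected Microsomal Half-Life

The source may hold more compounds than are shown below. What is called first, only, known or untested is meant among the compounds shown, and "the series" means these compounds.

Three compounds built on a shared amide core have been examined in an ADME assay on microsomes from liver (Rattus norvegicus, strain Sprague-Dawley) for metabolic stability, read by HPLC, using NADPH, with stated times of 5 min and 60 min, tested at 10 uM; on this read-out lower numbers stand for a shorter-lived compound and higher numbers for a longer-lived compound. Compound 1 `CC(C)(C)c1ccc(C(=O)NCc2ccc(NS(=O)(=O)C3CC3)cc2Cl)cc1` gives 0.55 h. Compound 2 `CC(C)(C)c1ccc(C(=O)NCc2c(Cl)cc(NS(C)(=O)=O)cc2Cl)cc1` gives 1.37 h. Compound 3 `CN(C)c1ccc(C(=O)NCc2ccc(NS(C)(=O)=O)cc2Cl)cc1` gives 0.883 h, a number that sits between those of the other two, yet its gap to compound 2 and its gap to compound 1 both lie within the usual scatter of repeated measurements, so no ranking of the three can be claimed from these values.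

Compound 4 `CS(=O)(=O)Nc1ccc(CNC(=O)c2ccc(CC(F)(F)F)cc2)c(Cl)c1` has not yet been tested in this assay. It differs from compound 3 in a single place: 2,2,2-trifluoroethyl in place of dimethylamino on an aromatic carbon. Among the measured compounds shown here, no two measured compounds in this set are separated by one change of that kind, so there is no measured step to lean on, and the expectation rests only on the three values already in hand and on the nature of the change.

The estimated step of a 1.1-fold higher number from compound 3 to compound 4 (0.05 log units; within the scatter) is expected to be small and most likely none beyond the scatter. Compound 4 is therefore expected to give 1 h in this assay, with a range from 0.5 h to 2.2 h.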

Compound 4, half-life: 1.03 h
The estimate for compound 4 lay 1.0-fold (0.01 log units) below the measured number; the measured number falls inside the stated range.
By their numbers in this assay, from the lowest: compounds 1, 3, 4 and 2 (each within the scatter of the next, the first and the last beyond it).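

In this assay, among the compounds shown here, the exchange of dimethylamino for 2,2,2-trifluoroethyl on an aromatic carbon, para to a large group, gives a 1.2-fold higher number from compound 3 to compound 4 (0.07 log units; within the scatter), the first step in this set that can be read at a single place. The step shows that this place accepts a group with 5 heavy atoms and no hydrogen-bond acceptor in place of one with 3 heavy atoms and 1 hydrogen-bond acceptor, with no difference in half-life beyond the scatter. Nothing available here accounts for this outcome or links it to any property of the two groups.

With only one step at this place, the compounds shown do not reveal whether other groups there, such as a carboxylic acid, a primary amine or a longer fluorinated chain, would also stay within the scatter of compound 3. They also leave open whether the same exchange would give a similar step on a core carrying a different sulfonamide substituent or a second chlorine, as in compound 1 and compound 2.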